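Swapping Fluorines for Methyls on a Cyclohexyl Amine

The source may hold more compounds than are shown below. What is called first, only, known or untested is meant among the compounds shown, and "the series" means these compounds.

Within the data shown here, compound 2 `CC(C)(CCN(C[C@H]1Cc2ccccc2CN1)[C@H]1CCCc2cccnc21)CNC1CCC(F)(F)CC1` gives 168 nM in a functional assay on cells for antagonist activity at C-X-C chemokine receptor type 4 (Homo sapiens), read by fluorescence and calcium flux, with stated times of 25 min and 90 s (on this read-out higher numbers stand for weaker inhibition and lower numbers for stronger inhibition), the higher of the two numbers measured so far, and compound 1 `CC(C)(CN)CCN(C[C@H]1Cc2ccccc2CN1)[C@H]1CCCc2cccnc21` gives 69 nM. Among the measured compounds shown here, the one step between them reads a 2.4-fold higher number from compound 1 to compound 2 (0.39 log units; beyond the scatter). Compound 3 `CC1(C)CCC(NCC(C)(C)CCN(C[C@H]2Cc3ccccc3CN2)[C@H]2CCCc3cccnc32)CC1` differs from compound 2 by 4,4-dimethylcyclohexyl in place of 4,4-difluorocyclohexyl on an amine nitrogen. For the measured compounds named here, no measured step bears directly on this kind of swap: the only step available, from compound 1 to compound 2, concerns adding the whole ring to a bare amine nitrogen, not changing the two substituents on that ring. With the ring kept and only its two substituents exchanged, no step beyond the scatter is expected, in either direction. Compound 3 is therefore estimated at 170 nM, with a range of 70 nM to 420 nM. This estimate means that a 1.0-fold higher number from compound 2 to compound 3 (0.01 log units; within the scatter) is expected.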

Compound 3, half-maximal inhibitory concentration in the C-X-C chemokine receptor type 4 assay: 541 nM
For compound 3 the middle estimate is 3.2-fold (0.50 log units) below the measured one; measured number above the stated range.
By their numbers in the C-X-C chemokine receptor type 4 assay, from the lowest: compound 1; then compound 2; then compound 3.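

In the C-X-C chemokine receptor type 4 assay the two substituents on the cyclohexyl ring matter, not only the presence of the ring: 4,4-dimethylcyclohexyl in place of 4,4-difluorocyclohexyl on the amine nitrogen gives a 3.2-fold higher number from compound 2 to compound 3 (0.51 log units; beyond the scatter), with compound 2 at 168 nM and compound 3 at 541 nM, even though both groups count the same number of heavy atoms. Measured against the bare amine, the dimethyl ring gives a 7.8-fold higher number from compound 1 to compound 3 (0.89 log units; beyond the scatter) and so lies further from compound 1 than the difluoro ring does. In a physicochemical assay for permeability, using PAMPA, with a stated time of 4 h, at pH 7.4, tested at 100 uM (on this read-out higher numbers stand for higher permeability and lower numbers for lower permeability), the same swap gives a 1.3-fold higher number from compound 2 to compound 3 (0.10 log units; within the scatter) and therefore does not separate the two compounds on apparent permeability, with compound 2 at 22 nm/s and compound 3 at 28 nm/s.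

Nothing at hand explains why the two rings differ in the calcium-flux read-out. From the compounds shown here alone, it also remains open how a hydroxyl group on the ring, or an open butyl chain in place of the ring, would compare with compound 1.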